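A few compounds are considered here, and "the series" means these few. Any claim that something is new, unique, unknown or untested is made for them only; others in the source may bear on it.

Values in an ADME assay (liver) for metabolic stability, with Liver microsome (Rattus norvegicus) as the target, using microsomes (a lower number here means slower removal, a higher number faster removal of the compound), for the measured compounds:
compound 1 `O=C(N1CCOCC1)N1CCC(Oc2ccc3c(c2)CCN(C2CCC2)CC3)CC1` gives 1.1 mL.min-1.g-1
compound 2 `c1cc2c(cc1OCC1CCNCC1)CCN(C1CCC1)CC2` gives 0.7 mL.min-1.g-1
compound 3 `c1ccc(COc2ccc3c(c2)CCN(C2CCCC2)CC3)cc1` gives > 50 mL.min-1.g-1 as a limit of the assay

In this assay compound 1 at 1.1 mL.min-1.g-1 and compound 2 at 0.7 mL.min-1.g-1 lie within the scatter of each other. The change 4-chlorophenyl in place of morpholin-4-yl on a carbonyl carbon leads from compound 1 to compound 4 `O=C(c1ccc(Cl)cc1)N1CCC(Oc2ccc3c(c2)CCN(C2CCC2)CC3)CC1` in one place. Within the data shown here, no measured pair of compounds differs in one place, so the size of this step rests on thin ground. A rise beyond the scatter is expected, since compound 3 gives > 50 mL.min-1.g-1 as a limit and also ends in a six-membered aromatic ring of carbon only. The expected step is a 4.5-fold higher number from compound 1 to compound 4 (0.66 log units; beyond the scatter) in the direction of faster removal. For compound 4 an estimated 5 mL.min-1.g-1 is expected, with a range from 1.5 mL.min-1.g-1 to 20 mL.min-1.g-1 around it.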

Compound 4, intrinsic clearance in microsomes: 2.9 mL.min-1.g-1
Compound 4: the middle estimate sits 1.7-fold (0.24 log units) above what was measured; the measured number falls inside the stated range.
By their numbers in this assay, from the lowest: compounds 2 and 1 (each within the scatter of the next); then compound 4. At a limit, above all of these: compound 3.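

In this assay, the carbonyl carbon proves to be a place where the group matters: 4-chlorophenyl in place of morpholin-4-yl gives a 2.6-fold higher number from compound 1 to compound 4 (0.42 log units; beyond the scatter), a modest rise and the first single-place step available here. Compound 3 alone stands at a limit of the assay, and compound 4, with its six-membered aromatic ring of carbon only on the carbonyl carbon, does not: the limit of > 50 mL.min-1.g-1 in this assay, at which 1 of the 4 values shown sits.

On these data alone, whether the rise belongs to the ring itself or to its chlorine stays open. So does how a plain phenyl, a pyridin-3-yl or a dimethylamino group would compare on the same carbonyl carbon.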